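Swapping the sulfonyl aryl group in a 5-HT6 antagonist series

The source may hold more compounds than are shown below. What is called first, only, known or untested is meant among the compounds shown, and "the series" means these compounds.

Measured compounds:
compound 1, `CN1CCC(N(C)C(=O)C2CN(S(=O)(=O)c3cccc4c(Cl)cccc34)c3ccccc32)CC1`, 5.01 nM
compound 2, `CN1CCC(N(C)C(=O)C2CN(S(=O)(=O)c3cccc4ccccc34)c3ccccc32)CC1`, 31.6 nM
compound 3, `Cc1c(S(=O)(=O)N2CC(C(=O)N(C)C3CCN(C)CC3)c3ccccc32)sc2ccc(Cl)cc12`, 63.1 nM

In a functional assay on CHO cells for antagonist activity at 5-hydroxytryptamine receptor 6 (Homo sapiens), read by FLIPR (on this read-out lower numbers stand for stronger inhibition and higher numbers for weaker inhibition), compound 3 gives the highest of the three numbers; compound 2 sits within the scatter of it, while compound 1 lies well apart, as a 13-fold higher number from compound 1 to compound 3 (1.10 log units; beyond the scatter) shows. Compound 4, `CN1CCC(N(C)C(=O)C2CN(S(=O)(=O)c3ccc(C(F)(F)F)cc3)c3ccccc32)CC1`, arises from compound 3 by 4-(trifluoromethyl)phenyl in place of 5-chloro-3-methyl-1-benzothiophen-2-yl on a sulfonyl sulfur. The two earlier changes at the same sulfonyl sulfur bear on this step: a 13-fold higher number from compound 1 to compound 3 (1.10 log units; beyond the scatter) and a 2.0-fold higher number from compound 2 to compound 3 (0.30 log units; within the scatter). Among the measured compounds shown here, both replaced one bicyclic group with another; here a single ring enters, so no direct precedent exists. Compound 4 is therefore expected to land near compound 3, with a 1.1-fold lower number from compound 3 to compound 4 (0.02 log units; within the scatter), and its estimated value in this assay is 60 nM (range 12 nM to 300 nM).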

Compound 4, inhibition constant: 25.1 nM
Compound 4: the middle estimate sits 2.4-fold (0.38 log units) above what was measured; the measured number falls inside the stated range.
By their numbers in this assay, from the lowest: compound 1; then compounds 4, 2 and 3 (each within the scatter of the next, the first and the last beyond it).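

A single aromatic ring on the sulfonyl sulfur holds up in this series: 4-(trifluoromethyl)phenyl gives a 2.5-fold lower number from compound 3 to compound 4 (0.40 log units; beyond the scatter) and a 1.3-fold lower number from compound 2 to compound 4 (0.10 log units; within the scatter) against the two bicyclic groups, so a second fused ring is not needed to reach this range. It does not match 5-chloronaphthalen-1-yl, however, as a 5.0-fold higher number from compound 1 to compound 4 (0.70 log units; beyond the scatter) shows. Nothing measured here gives a reason for these steps. The compounds shown leave open whether an amine or a carboxylic acid in place of trifluoromethyl on the phenyl ring would keep this level, and what an unsubstituted phenyl would give.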